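This account rests on a few compounds, and the source may have more. Where it says the series, first, only, none or still open, it means among the compounds named here.

Three compounds share one core and differ only in the aryl group on the ring nitrogen of the five-membered aromatic ring with three nitrogens. Compound 1 `CC(C)n1ncc2c(C(=O)NCc3cn(-c4ccc(F)cc4)nn3)cccc21` carries a 4-fluorophenyl there, compound 2 `CC(C)n1ncc2c(C(=O)NCc3cn(-c4cccc(F)c4)nn3)cccc21` a 3-fluorophenyl, and compound 3 `Cc1cccc(-n2cc(CNC(=O)c3cccc4c3cnn4C(C)C)nn2)c1` a 3-methylphenyl. In a functional assay on HepG2 cells (Homo sapiens) for inhibition, read by MTT assay, with a stated time of 72 h (a higher number here means a weaker inhibitor, a lower number a stronger inhibitor), compound 1 gives only a limit, > 40000 nM. In this assay compound 2 likewise gives a limit, > 40000 nM. In this assay compound 3 also reaches only a limit, > 40000 nM. Compound 3 therefore stands nowhere distinguishable from its two companions: all three sit at the limit of > 40000 nM in this assay, at which 3 of the 3 values shown sit. The steps between them cannot be sized, a step that the two limits leave unreadable from compound 1 to compound 2, a step that the two limits leave unreadable from compound 1 to compound 3 and a step that the two limits leave unreadable from compound 2 to compound 3.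

The next compound, compound 4 `CC(C)n1ncc2c(C(=O)NCc3cn(-c4ccccc4F)nn3)cccc21`, changes the aryl group again: 2-fluorophenyl in place of 3-methylphenyl on an aromatic nitrogen. The measured steps that bear on this move are the three unreadable ones just named, each joining two limits, so none of them gives a direction or a size in this assay. Nothing in the three measurements suggests that a single aryl change lifts the series into a readable number. Compound 4 is accordingly expected to give 45000 nM, with a range from 20000 nM to 100000 nM. That corresponds to an expected step that the limit leaves unreadable from compound 3 to compound 4.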

Compound 4, half-maximal inhibitory concentration: > 40000 nM
Compound 4: only a limit was reported; the forecaster's own chance of this, stated with the estimate: 85%; the middle value does not contradict the limit.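

Compound 4 also reaches only a limit in this assay, so none of its steps to compound 1, compound 2 or compound 3 can be read, and the four compounds cannot be told apart: the limit of > 40000 nM in this assay, at which 4 of the 4 values shown sit. The compounds shown leave open whether any aryl group on this aromatic nitrogen gives a readable number in this assay.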